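Removing the methoxy from compound 1

The source may hold more compounds than are shown below. What is called first, only, known or untested is meant among the compounds shown, and "the series" means these compounds.

Values in an ADME assay on HEK293 cells (Homo sapiens) for cytotoxicity, read by resazurin assay, with a stated time of 16 h; on this read-out higher numbers stand for an effect only at larger amounts of compound and lower numbers for an effect already at smaller amounts:
- compound 1 `COc1ccc(/C=C/C(=O)CC(=O)/C=C/c2ccc(O)c(OC)c2)cc1`: 79000 nM
- compound 2 `COc1ccc(/C=C/C(=O)CC(=O)/C=C/c2ccc(OC)c(OC)c2)cc1`: 690000 nM

Compound 1 holds the lower of the two numbers. Compound 3 `COc1ccc(/C=C/C(=O)CC(=O)/C=C/c2ccc(O)cc2)cc1` is still unmeasured and differs from it by hydrogen in place of methoxy on an aromatic carbon. Going by the values given here, the only measured step, an 8.7-fold higher number from compound 1 to compound 2 (0.94 log units; beyond the scatter), is methyl in place of hydrogen on an oxygen on an aromatic ring. It bears only indirectly, since compound 3 keeps its hydroxy group. In this assay, a smaller step towards a somewhat higher number is therefore expected, possibly none beyond the scatter. The expected change is a 1.5-fold higher number from compound 1 to compound 3 (0.18 log units; within the scatter). Compound 3 is estimated at 120000 nM, with an expected range of 40000 nM to 350000 nM.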

Compound 3, half-maximal effective concentration: 400000 nM
The estimate for compound 3 lay 3.3-fold (0.52 log units) below the measured number; the measured number lies above the stated range.
By their numbers in this assay, from the lowest: compound 1; then compounds 3 and 2 (each within the scatter of the next).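

In this assay, the methoxy ortho to a hydroxy group proves to matter in its own right: replacing it with hydrogen gives a 5.1-fold higher number from compound 1 to compound 3 (0.70 log units; beyond the scatter), although the hydroxy group stays. The low number of compound 1 therefore does not rest on the hydroxy group alone, since placing methyl on that oxygen also raises the number, giving an 8.7-fold higher number from compound 1 to compound 2 (0.94 log units; beyond the scatter). As far as these compounds go, whether an ethoxy group, a fluorine atom or an amine at this position would keep the number of compound 1 remains open. No measured evidence offers a cause for either step.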